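Compound 4 and the Limit of the Sulfonyl Series

The compounds below may be only part of what the source reports. "The series", "measured", "known", "first", "only" and "open" are said of these compounds alone.

Of the compounds shown here, three sharing one core have been tested in a functional assay on SGC-7901 cells (Homo sapiens) for antiproliferative activity, read by MTT assay, with a stated time of 48 h; a higher number here means that more compound is needed for the effect, a lower number that less compound is needed. Compound 1 (`CC1=NN(S(=O)(=O)c2ccc(F)cc2)C(c2cc(Br)ccc2O)C1`) returns only a limit (> 60000 nM). Compound 2 (`CC1=NN(S(=O)(=O)c2ccc(Cl)cc2)C(c2cc(Br)ccc2O)C1`) also returns only a limit (> 60000 nM). Compound 3 (`CC1=NN(S(=O)(=O)c2ccc(Cl)cc2Cl)C(c2cc(Br)ccc2O)C1`) stands at a limit too (> 60000 nM), so it has no number of its own. The series thus rests on the limit of > 60000 nM in this assay, at which 3 of the 3 values shown sit, and nothing firmer. Compound 4 (`CC1=NN(S(=O)(=O)c2ccccc2I)C(c2cc(Br)ccc2O)C1`) changes one group of compound 3 (2-iodophenyl in place of 2,4-dichlorophenyl on a sulfonyl sulfur), with 2-iodophenyl in place of 2,4-dichlorophenyl on a sulfonyl sulfur. The nearest measured changes also concern that aryl group, but they show a step that the two limits leave unreadable from compound 1 to compound 2 along with a step that the two limits leave unreadable from compound 1 to compound 3 and a step that the two limits leave unreadable from compound 2 to compound 3 and so give no size to carry over. No step beyond the scatter is therefore expected, in either direction, and compound 4 will most likely be reported at the same limit. The estimated change is a number no higher from compound 3 to compound 4 (the limit leaves the size open) and it carries little weight. In this assay the expected value for compound 4 is 60000 nM (25000 nM to 100000 nM).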

Compound 4, half-maximal effective concentration: > 60000 nM
Compound 4: a limit, no number; the forecaster's own chance of this, stated with the estimate: 80%; the middle value lies on the limit itself.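

In this assay compound 4 gives > 60000 nM as a limit and no number. Its steps from compound 1, compound 2 and compound 3 cannot be read, and the series stays at a single limit: the limit of > 60000 nM in this assay, at which 4 of the 4 values shown sit. The compounds shown leave open whether any aryl group on the sulfonyl sulfur gives a measurable value in this assay at all.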